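The compounds below may be only part of what the source reports. "The series", "measured", "known", "first", "only" and "open" are said of these compounds alone.

Three compounds share one core and differ only in the groups hung on it. Compound 1 `COc1cc(C)cc(-c2c(-c3ccnc(-c4ccc(C(C)=O)cc4)c3)cnn2CC#N)c1` gives 3630 nM in a functional assay on MDA-MB-231 cells (Homo sapiens) for inhibition, read by sulforhodamine B assay, with a stated time of 48 h (a lower number here means a stronger inhibitor of growth, a higher number a weaker inhibitor of growth), compound 2 `COc1cc(C)cc(-c2nn(CC#N)cc2-c2ccc(-c3cccc(C(C)=O)c3)nc2)c1` gives 3040 nM, and compound 3 `Cc1cc(O)cc(-c2nn(CC#N)cc2-c2ccnc(-c3ccc(Oc4ccccc4)cc3)c2)c1` gives 2280 nM. Compound 3 carries the lowest of the three numbers, but its gaps to compound 2 and to compound 1 both lie within the ordinary scatter of the measurement, so no one of the three can be called the strongest on this evidence.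

Compound 4 `Cc1cc(O)cc(-c2nn(CC#N)cc2-c2ccnc(-c3ccc(N(C)C)cc3)c2)c1` has not yet been measured. It departs from compound 3 in a single place: dimethylamino in place of phenoxy on an aromatic carbon. No measured pair shows what such an exchange does on this core, so there is no shown step to lean on. The expectation is therefore cautious: a change of modest size, in either direction, quite possibly none beyond the scatter, with the step from compound 3 to compound 4 estimated as a 1.3-fold higher number from compound 3 to compound 4 (0.12 log units; within the scatter). Compound 4 is expected to give 3000 nM in this assay, within a range from 1200 nM to 8000 nM.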

Compound 4, concentration for 50% growth inhibition: 2940 nM
Estimate against measurement, compound 4: 1.0-fold (0.01 log units) above, within the range that was stated.
By their numbers in this assay, from the lowest: compounds 3, 4, 2 and 1 (each within the scatter of the next).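

In this assay, among these compounds, the exchange of phenoxy for dimethylamino on an aromatic carbon, para to a large group, gives a 1.3-fold higher number from compound 3 to compound 4 (0.11 log units; within the scatter) and is the first one-place comparison available on the shared core. At this position, then, a six-membered aromatic ring of carbon can leave and a smaller group with no ring can enter, and the two compounds still cannot be told apart in growth inhibition. Nothing measured here bears on the reason for this result.

A single pair cannot show whether this position tolerates other groups in general, or whether the same exchange would give a similar result on other compounds of the series. A primary amine or a carboxylic acid at this place, or a longer chain ending in an amine, could still give a clearly different number.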